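Compound 4 and a relocated methoxy group

A few compounds are considered here, and "the series" means these few. Any claim that something is new, unique, unknown or untested is made for them only; others in the source may bear on it.

Three compounds on a shared core, differing only in the group on the sulfonyl sulfur, have been measured in an ADME assay on the whole organism (plasma, Rattus norvegicus, strain Sprague-Dawley) for pharmacokinetics, read by LC-MS, using cassette dosing, at a dose of 0.2 mg/kg by the intravenous route; a higher number here means more compound in the circulation at the dose given, a lower number less compound in the circulation. Compound 1 (`CNCc1cn(S(=O)(=O)c2ccoc2)c(-c2cccnc2F)c1F`), with furan-3-yl, gives 41 ng.h/mL. Compound 2 (`CNCc1cn(S(=O)(=O)c2ccccn2)c(-c2cccnc2F)c1F`), with pyridin-2-yl, gives 33 ng.h/mL, and the exchange amounts to a 1.2-fold lower number from compound 1 to compound 2 (0.09 log units; within the scatter). Compound 3 (`CNCc1cn(S(=O)(=O)c2cccc(OC)n2)c(-c2cccnc2F)c1F`), with 6-methoxypyridin-2-yl, gives 50 ng.h/mL. It stands level with the other two within the scatter, as shown by a 1.2-fold higher number from compound 1 to compound 3 (0.09 log units; within the scatter) and a 1.5-fold higher number from compound 2 to compound 3 (0.18 log units; within the scatter).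

Compound 4 (`CNCc1cn(S(=O)(=O)c2ccc(OC)cn2)c(-c2cccnc2F)c1F`) keeps the same atoms but joins them differently: 5-methoxypyridin-2-yl in place of 6-methoxypyridin-2-yl on a sulfonyl sulfur. In words, 5-methoxypyridin-2-yl stands in place of 6-methoxypyridin-2-yl on a sulfonyl sulfur. Going by the values given here, no measured pair tests this exact exchange. The closest evidence is a 1.5-fold higher number from compound 2 to compound 3 (0.18 log units; within the scatter), which adds the methoxy group, together with a 1.2-fold higher number from compound 1 to compound 3 (0.09 log units; within the scatter), which replaces the whole group. Neither leaves the scatter, so a relocated methoxy group is not expected to move this assay beyond it. The estimated change is a 1.2-fold lower number from compound 3 to compound 4 (0.08 log units; within the scatter), which is no real step in either direction. For compound 4 the expected area under the curve is 42 ng.h/mL, with an estimated range of 22 ng.h/mL to 80 ng.h/mL.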

Compound 4, area under the concentration-time curve: 52 ng.h/mL
Compound 4: middle estimate off by 1.2-fold (0.09 log units), on the low side, and the stated range covers the measured number.
By their numbers in this assay, from the lowest: compounds 2, 1, 3 and 4 (each within the scatter of the next).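

In this assay, going by these compounds alone, the exchange of 6-methoxypyridin-2-yl for 5-methoxypyridin-2-yl on the sulfonyl sulfur gives a 1.0-fold higher number from compound 3 to compound 4 (0.02 log units; within the scatter) and so offers the first direct reading of where the methoxy group sits, with no difference between the two placements to be seen. Read against pyridin-2-yl, the 5-methoxypyridin-2-yl group gives a 1.6-fold higher number from compound 2 to compound 4 (0.20 log units; within the scatter) and, read against furan-3-yl, it gives a 1.3-fold higher number from compound 1 to compound 4 (0.10 log units; within the scatter) as well, so the second placement, like the first, stays inside the scatter against both earlier groups. All four groups on the sulfonyl sulfur therefore stand level in this measurement, and nothing measured here bears on what lies behind that result.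

The compounds shown carry only furan-3-yl, pyridin-2-yl and its two methoxy forms, so it remains open whether an amine or a carboxylic acid on the pyridin-2-yl group, or a longer alkoxy chain in place of methoxy, would leave the scatter in this assay at all. As far as these compounds go, the shared core is also constant throughout, so whether this level picture would hold on a different core remains unknown.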